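Aryl exchange at the weak end of a cytotoxicity series

This account rests on a few compounds, and the source may have more. Where it says the series, first, only, none or still open, it means among the compounds named here.

Three compounds have been measured in a functional assay on A549 cells (Homo sapiens) for cytotoxicity, read by MTT assay, with a stated time of 72 h; on this read-out lower numbers stand for stronger inhibition and higher numbers for weaker inhibition:
compound 1 `O=C(Nc1ccc(Oc2ccnc3[nH]ccc23)c(F)c1)c1nn(-c2ccc(Cl)c(F)c2)ccc1=O` — 10300 nM
compound 2 `Cn1ccc2c(Oc3ccc(NC(=O)c4nn(-c5ccc(Br)cc5)ccc4=O)cc3)ccnc21` — 59400 nM
compound 3 `Cn1ccc2c(Oc3ccc(NC(=O)c4nn(-c5ccc(Br)cc5)ccc4=O)cc3F)ccnc21` — > 60000 nM, a limit of the assay

Compound 3 stands at the limit of this assay, > 60000 nM, and gives no number; only the values of compound 1 and compound 2 are read as numbers. Going by the values given here, the one measured step, a number no lower from compound 2 to compound 3 (the limit leaves the size open), concerns a fluoro in place of hydrogen and cannot be sized. Compound 4 `Cn1ccc2c(Oc3ccc(NC(=O)c4nn(-c5ccc(Cl)c(F)c5)ccc4=O)cc3F)ccnc21` is not yet measured. It differs from compound 3 by 4-chloro-3-fluorophenyl in place of 4-bromophenyl on an aromatic nitrogen. Among the compounds with values here, no measured step covers this exchange of aryl groups. Within the data shown here, compound 1 carries the same 4-chloro-3-fluorophenyl and the same fluoro as compound 4 but differs from it elsewhere in the shared core, and compound 1 gives 10300 nM in this assay; no step is known for that pair, so only the two values can be set side by side. Compound 4 is therefore expected at 40000 nM, between 10000 nM and 150000 nM. The expected step of an at least 1.5-fold lower number from compound 3 to compound 4 (0.17 log units; that floor lies within the scatter) is an estimate only, since compound 3 gives a limit.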

Compound 4, half-maximal inhibitory concentration: > 60000 nM
Compound 4: a limit, no number (the forecaster's own chance of this, stated with the estimate: 40%); middle value at least 1.5-fold (0.17 log units) away from the limit.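

In this assay compound 4 gives > 60000 nM, which is a limit of the assay and not a number. With the aryl group on the aromatic nitrogen changed, the step between the two compounds that carry these aryl groups on the methylated core cannot be read, as is true of every step ending in a limit, because both ends of the exchange sit at one ceiling: the limit of > 60000 nM in this assay, at which 2 of the 4 values shown sit.

What the result adds lies at the other aromatic nitrogen, where an at least 5.8-fold higher number from compound 1 to compound 4 (0.76 log units; beyond the scatter) marks methyl in place of hydrogen as a change that costs activity beyond the scatter, with the 4-chloro-3-fluorophenyl and the fluoro held the same.

From the compounds shown here alone, whether 4-bromophenyl would respond to that methyl in the same way stays open. So does the effect of an amine or a carboxylic acid on the aryl ring in place of its halogens.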